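Methoxy for trifluoromethyl on the aniline of an enaminone

This account rests on a few compounds, and the source may have more. Where it says the series, first, only, none or still open, it means among the compounds named here.

Measured so far:
Compound 1 `COc1ccc(N/C=C\C(=O)c2cn(-c3ccccc3)nc2-c2ccc(Cl)cc2)cc1`: 10700 nM
Compound 2 `COc1ccc(-c2nn(-c3ccccc3)cc2C(=O)/C=C\Nc2ccc(C(F)(F)F)cc2)cc1`: > 50000 nM

Two compounds share an enaminone core carrying an aryl-substituted pyrazole. In a functional assay on PC-3 cells (Homo sapiens) for antiproliferative activity, read by MTT assay, with a stated time of 48 h (a lower number here means a stronger inhibitor, a higher number a weaker inhibitor), compound 1 gives 10700 nM. Compound 2 gives only a limit, > 50000 nM, so no number is known for it; this is one of the two results that sit at the limit of > 50000 nM in this assay, at which 1 of the 2 values shown sits. Compound 2 therefore stands at the weak end of what has been measured here, while compound 1 gives a numeric value.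

Compound 3 `COc1ccc(N/C=C\C(=O)c2cn(-c3ccccc3)nc2-c2ccc(OC)cc2)cc1` has not yet been tested. It differs from compound 2 in one place: methoxy in place of trifluoromethyl on an aromatic carbon. Because compound 1, which carries the same methoxyphenylamino group, gives 10700 nM, compound 3 is expected to move toward a measurable value. The step of an at least 2.5-fold lower number from compound 2 to compound 3 (0.39 log units; beyond the scatter) is estimated to be a gain in potency beyond the scatter. Compound 3 is expected near 20000 nM, within a range from 6000 nM to 60000 nM.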

Compound 3, half-maximal inhibitory concentration: 13400 nM
Beside the measured number, compound 3's estimate is 1.5-fold (0.17 log units) above it; the range from low to high includes it.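

In this assay, putting methoxy in place of trifluoromethyl on an aromatic carbon of the aniline ring, para to a large group, gives an at least 3.7-fold lower number from compound 2 to compound 3 (0.57 log units; beyond the scatter), so this position does respond to the choice of group, and the change is large enough to bring the result to a measured number. The result for compound 2 is a limit of the assay and not a number, so the real size of this step remains unknown: the limit of > 50000 nM in this assay, at which 1 of the 3 values shown sits.

The second comparison concerns a different place, where methoxy stands in place of chloro on an aromatic carbon, and it gives a 1.3-fold higher number from compound 1 to compound 3 (0.10 log units; within the scatter), which lies within the scatter, so this assay does not tell these two groups apart there while both compounds carry the (4-methoxyphenyl)amino group.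

The compounds shown do not settle whether methoxy itself supports the activity or whether the step mainly reflects the loss of trifluoromethyl, a question that a plain hydrogen, a hydroxyl or an amine at the same place on the aniline ring could address. From the compounds shown here alone, it also remains open whether any group at either place could move the number well past those of compound 1 and compound 3.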